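Oxindole series: alkynyl amino-alcohol side chain variation

The source may hold more compounds than are shown below. What is called first, only, known or untested is meant among the compounds shown, and "the series" means these compounds.

Measured so far:
- Compound 1, `COc1cc[nH]c1/C=C1/C(=O)Nc2ccc(F)cc21`: > 30000 nM
- Compound 2, `COc1cc[nH]c1/C=C1\C(=O)Nc2ccc(F)c(C#C[C@H](N)CO)c21`: 320 nM

In a functional assay on MDA-MB-435 cells (Homo sapiens) for inhibition (on this read-out lower numbers stand for stronger inhibition and higher numbers for weaker inhibition), compound 1 reaches only a limit, > 30000 nM, and gives no number. Among the compounds with values here, compound 2 is therefore the only compound with a measured number in this assay, 320 nM; the other entry sits at the limit of > 30000 nM in this assay, at which 1 of the 2 values shown sits.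

Compound 3, `CCN[C@H](C#Cc1c(F)ccc2c1/C(=C/c1[nH]ccc1OC)C(=O)N2)[C@@H](C)O`, has not yet been measured in this assay. It differs from compound 2 by 1-(ethylamino)-2-hydroxypropyl in place of 1-amino-2-hydroxyethyl on a triple-bonded carbon. Within the data shown here, no pair of measured compounds shows the effect of such a change, so the expectation rests on compound 2 alone. The step of a 1.3-fold lower number from compound 2 to compound 3 (0.11 log units; within the scatter) is expected to stay within or near the usual scatter, with no clear direction. Compound 3 is estimated at 250 nM in this assay, with a range from 60 nM to 1200 nM.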

Compound 3, half-maximal inhibitory concentration: 1070 nM
Estimate against measurement, compound 3: 4.3-fold (0.63 log units) below, and the stated range covers the measured number.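

In this assay, within the data shown here, this is the first measured change on the triple-bonded carbon, and the position is not indifferent to it: replacing 1-amino-2-hydroxyethyl with 1-(ethylamino)-2-hydroxypropyl gives a 3.3-fold higher number from compound 2 to compound 3 (0.52 log units; beyond the scatter). The larger side chain, with its second defined stereocentre, still leaves compound 3 with a measured number, 1070 nM, and not a limit. Nothing in the data shown accounts for the step.

The change alters the amine and the carbon chain at once, so a 1-(ethylamino)-2-hydroxyethyl or a 1-amino-2-hydroxypropyl group would be needed to tell which part carries the step. On these data alone, the role of the added stereocentre also remains open, as does the outcome with a longer chain or a dimethylamino group at this position.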